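Cytotoxicity of Two Conjugates and a Shortened Analogue

The source may report more compounds than this note shows. Statements on the series, on what has been measured and on what is new or still open speak of the compounds shown alone.

Measured so far:
compound 1, `COc1ccc(-n2c3cssc-3c(NC(=O)OCCOC(=O)CCCCC(=O)c3c(O)cc(C)oc3=O)c2=O)c(OC)c1`: 9430 nM
compound 2, `COc1ccc(-n2c3cssc-3c(NC(=O)N(C)CCOC(=O)CCCCC(=O)c3c(O)cc(C)oc3=O)c2=O)c(OC)c1`: 2760 nM

In an ADME assay on HepG2 cells (Homo sapiens) for cytotoxicity, read by MTT assay (a higher number here means a weaker inhibitor, a lower number a stronger inhibitor), compound 1 gives 9430 nM. Among the measured compounds shown here, of the two numbers known in this assay, compound 1 stands highest; the nearest is compound 2, which in this assay gives 2760 nM, a lower number and a gap that lies beyond the usual scatter. For the measured compounds named here, compound 1 and compound 2 differ in more than one place, so no single step between them can be drawn, and only what their two values show is stated here.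

The account now turns to compound 3, `COc1ccc(-n2c3cssc-3c(NC(=O)OCCOC(=O)CCCC(=O)c3c(O)cc(C)oc3=O)c2=O)c(OC)c1`, which is not yet measured in this assay. Compound 3 differs from compound 1 in one place: a group of 11 heavy atoms (7 carbon, 4 oxygen; one six-membered aromatic ring with 1 hetero atom) in place of a group of 12 heavy atoms (8 carbon, 4 oxygen; one six-membered aromatic ring with 1 hetero atom), on a saturated chain carbon, three bonds along the chain from a carbonyl carbon. The change shortens the chain by a single carbon while leaving the ring and the rest of the group unchanged. On the numbers at hand, such a change is expected to move the cytotoxicity little, and the step of a 1.0-fold lower number from compound 1 to compound 3 (0.02 log units; within the scatter) is estimated to fall within the scatter rather than beyond it. Compound 3 is therefore expected to give about 9000 nM in this assay, within a range from 4000 nM to 20000 nM.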

Compound 3, half-maximal inhibitory concentration: 1970 nM
Compound 3: the middle estimate sits 4.6-fold (0.66 log units) above what was measured, and the stated range ends above it.
By their numbers in this assay, from the lowest: compounds 3 and 2 (each within the scatter of the next); then compound 1.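

In this assay, the place on a saturated chain carbon, three bonds along the chain from a carbonyl carbon, proves sensitive to a small change: a group of 11 heavy atoms (7 carbon, 4 oxygen; one six-membered aromatic ring with 1 hetero atom) in place of a group of 12 heavy atoms (8 carbon, 4 oxygen; one six-membered aromatic ring with 1 hetero atom) gives a 4.8-fold lower number from compound 1 to compound 3 (0.68 log units; beyond the scatter) and leaves the ring in the group unchanged. Among the compounds shown here, compound 1 and compound 2 differ in more than one place and offered no such reading, so this is the first change here whose effect can be seen on its own. Nothing among the data shown explains why the group with fewer heavy atoms gives the lower number.

The compounds shown leave open whether the same change would move the number in the same direction on the background of compound 2, since this single pair cannot show whether the step depends on the rest of the molecule. They also leave open how a longer chain, or an amine or a carboxylic acid at this place, would read in this assay as compared with compound 1 and compound 3.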